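Phenethyl for furan-2-yl on a second core

A few compounds are considered here, and "the series" means these few. Any claim that something is new, unique, unknown or untested is made for them only; others in the source may bear on it.

Measured compounds:
Compound 1 `O=C(Nn1c(-c2cccc([N+](=O)[O-])c2)nc2c(-c3ccco3)n[nH]c2c1=O)c1cccnc1`: 1.51%
Compound 2 `O=C(Nn1c(-c2cccc([N+](=O)[O-])c2)nc2c(CCc3ccccc3)n[nH]c2c1=O)c1cccnc1`: 19%
Compound 3 `O=C(Nn1c(-c2cccc([N+](=O)[O-])c2)nc2c(-c3ccco3)n[nH]c2c1=O)c1ccccc1`: 18.7%

Of the compounds shown here, three have been read in a functional assay on A549 cells (Homo sapiens) for cytotoxicity, read by sulforhodamine B assay, with a stated time of 2 days, tested at 100 uM; on this read-out higher numbers stand for more inhibition at the one concentration tested (going by the name of the read-out) and lower numbers for less inhibition. Compound 1 gives 1.51% there. Compound 2, which carries the change (phenethyl in place of furan-2-yl on an aromatic carbon), gives 19%, so that the step of a number 17.5 percentage points higher from compound 1 to compound 2 (beyond the scatter) is a modest rise. The change phenyl in place of pyridin-3-yl on a carbonyl carbon leads from compound 1 to compound 3, and compound 3 gives 18.7%; the step of a number 17.2 percentage points higher from compound 1 to compound 3 (beyond the scatter) is of about the same size. The values of compound 2 and compound 3 lie within the scatter of each other.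

The unmeasured compound 4 `O=C(Nn1c(-c2cccc([N+](=O)[O-])c2)nc2c(CCc3ccccc3)n[nH]c2c1=O)c1ccccc1` stands to compound 3 as compound 2 stands to compound 1: the change phenethyl in place of furan-2-yl on an aromatic carbon is the same change that was made from compound 1 to compound 2, at the same place, with the two cores differing only in the way already described for compound 3 against compound 1. Whether the step repeats on the core of compound 3 cannot be read from the data, since compound 3 already sits higher than compound 1. A step of a number 11.3 percentage points higher from compound 3 to compound 4 (beyond the scatter) is expected in this assay, smaller than the earlier one because the starting point of compound 3 at 18.7% is already raised. Compound 4 is thus estimated at 30%, with an expected range from 12% to 50%.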

Compound 4, a percentage reported as inhibition, at one concentration (the size of the read-out at that concentration, not a potency): 73.9%
For compound 4 the middle estimate is 43.9 percentage points below the measured one; measured number above the stated range.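

In this assay, phenethyl in place of furan-2-yl brings a number 55.2 percentage points higher from compound 3 to compound 4 (beyond the scatter), and phenyl in place of pyridin-3-yl on a carbonyl carbon brings a number 54.9 percentage points higher from compound 2 to compound 4 (beyond the scatter). The phenethyl change keeps its direction on the second core but not its size, so the step seen on one core did not give the size of the step on the other: the same change on two cores in this assay, a number 17.5 percentage points higher (beyond the scatter) from compound 1 to compound 2 and a number 55.2 percentage points higher (beyond the scatter) from compound 3 to compound 4, 37.7 percentage points apart, beyond the scatter of two such steps. The phenyl change behaves the same way, and since both comparisons rest on the same four compounds they show a single case in which the two changes together give more than their separate steps would suggest, without showing why this happens or whether it would recur on any other core: the same change on two cores in this assay, a number 17.2 percentage points higher (beyond the scatter) from compound 1 to compound 3 and a number 54.9 percentage points higher (beyond the scatter) from compound 2 to compound 4, 37.7 percentage points apart, beyond the scatter of two such steps.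

The compounds shown leave open whether the large step belongs to phenethyl itself or would also appear with a shorter or longer chain, such as benzyl or 3-phenylpropyl, on that aromatic carbon. They also leave open whether the combined effect would survive with an amine in place of the nitro group that all four compounds share.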